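Thiophen-2-yl to 3-Fluorophenyl: An Expected Potency Shift

The source may hold more compounds than are shown below. What is called first, only, known or untested is meant among the compounds shown, and "the series" means these compounds.

Of the compounds shown here, three sharing one core have been tested in a functional assay on MDA-MB-231 cells (Homo sapiens) for cytotoxicity, read by MTT assay, with a stated time of 48 h; a lower number here means a stronger inhibitor, a higher number a weaker inhibitor. Compound 1 `O=C(/C=C/c1ccc2c(c1)B(O)OC2)c1ccc(-c2ccccc2)cc1` gives 6400 nM, compound 2 `O=C(/C=C/c1ccc2c(c1)B(O)OC2)c1cccs1` gives 4600 nM, and compound 3 `O=C(/C=C/c1ccc2c(c1)B(O)OC2)c1ccc(F)cc1` gives 1600 nM. Compound 2 thus has the second highest number of the three; its gap to compound 1 lies within the scatter, while its gap to compound 3 lies beyond it.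

Compound 4 `O=C(/C=C/c1ccc2c(c1)B(O)OC2)c1cccc(F)c1` has not yet been measured. It differs from compound 2 in one place: 3-fluorophenyl in place of thiophen-2-yl on a carbonyl carbon.

Going by the values given here, two measured steps bear on this change. Most directly, a 2.9-fold lower number from compound 2 to compound 3 (0.46 log units; beyond the scatter), where 4-fluorophenyl replaced thiophen-2-yl on the same carbonyl carbon. In addition, a 4.0-fold lower number from compound 1 to compound 3 (0.60 log units; beyond the scatter), where fluoro took the place of phenyl on an aromatic carbon. Among the compounds with values here, compound 4 carries 3-fluorophenyl rather than the 4-fluorophenyl of compound 3, and no measured pair shows what that difference does, so the expectation rests on compound 3 with added uncertainty. Compound 4 is therefore expected to show a 1.8-fold lower number from compound 2 to compound 4 (0.26 log units; within the scatter) in this assay, a modest move toward a lower number. The estimate for compound 4 is 2500 nM, with a likely range from 1000 nM to 6000 nM.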

Compound 4, half-maximal inhibitory concentration: 3000 nM
Compound 4: the middle estimate sits 1.2-fold (0.08 log units) below what was measured, within the range that was stated.
By their numbers in this assay, from the lowest: compounds 3, 4, 2 and 1 (each within the scatter of the next, the first and the last beyond it).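

In this assay, replacing thiophen-2-yl on the carbonyl carbon with 3-fluorophenyl gives a 1.5-fold lower number from compound 2 to compound 4 (0.19 log units; within the scatter) and so, unlike the swap to 4-fluorophenyl in compound 3, cannot be told apart from the ordinary scatter of repeated measurements. Going by these compounds alone, the result also offers the first direct comparison of the two fluorophenyl groups at this place: a 1.9-fold higher number from compound 3 to compound 4 (0.27 log units; within the scatter) is what this assay records, so the data do not separate them. Compound 4 therefore lies within the scatter of both compound 2 and compound 3, even though those two stand clearly apart, and it cannot be assigned to either side of that gap.

The compounds shown leave open how this place on the carbonyl carbon would respond to a quite different group, such as a phenyl ring carrying an amine, a carboxylic acid or a methoxy group, or a longer chain in place of the ring. No measured evidence here explains any of these numbers.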